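Ring nitrogen returns to the methoxy-bearing aryl group

A few compounds are considered here, and "the series" means these few. Any claim that something is new, unique, unknown or untested is made for them only; others in the source may bear on it.

Of the compounds shown here, three with a shared core have been measured in a functional assay on BJAB cells (Homo sapiens) for antiproliferative activity, with a stated time of 4 days; on this read-out lower numbers stand for an effect already at smaller amounts and higher numbers for an effect only at larger amounts of compound. Compound 1 `Cc1nn(-c2nc(-c3ccc(Cl)c(Cl)c3)c(SC(C)C)s2)c(C(=O)O)c1-c1cncnc1` gives 22000 nM, compound 2 `Cc1c(-c2cc(Cl)cc(Cl)c2)c(C(=O)O)nn1-c1nc(-c2cc(Cl)ccc2F)c(SC(C)C)s1` gives 4800 nM, and compound 3 `COc1ccc(-c2c(C)nn(-c3nc(-c4ccc(Cl)c(Cl)c4)c(SC(C)C)s3)c2C(=O)O)cc1` gives 2100 nM. Compound 3 stands lowest of the three; its nearest neighbour is compound 2, which is beyond the scatter away, and the furthest is compound 1. Among the measured compounds shown here, the only single-site step among the measured compounds is a 10-fold lower number from compound 1 to compound 3 (1.02 log units; beyond the scatter), where 4-methoxyphenyl replaced pyrimidin-5-yl on an aromatic carbon.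

Compound 4 `COc1cncc(-c2c(C)nn(-c3nc(-c4ccc(Cl)c(Cl)c4)c(SC(C)C)s3)c2C(=O)O)c1` is not yet measured. It differs from compound 3 by 5-methoxypyridin-3-yl in place of 4-methoxyphenyl on an aromatic carbon. The entering group keeps the methoxy substituent but brings one six-membered aromatic ring with 1 hetero atom and 2 hydrogen-bond acceptors in place of a ring of carbon only with 1 acceptor, which is partway back toward the ring of compound 1. The step from compound 1 to compound 3 is the one that bears on this change, and it was large. Since compound 4 retains the methoxy group, only part of that effect is expected to reverse, so a modest step upward in this assay, a 2.4-fold higher number from compound 3 to compound 4 (0.38 log units; beyond the scatter), is estimated. Compound 4 is therefore expected to give about 5000 nM, in the range 2000 nM to 15000 nM.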

Compound 4, half-maximal effective concentration: 21000 nM
Compound 4: the middle estimate sits 4.2-fold (0.62 log units) below what was measured; measured number outside the range, above it.
By their numbers in this assay, from the lowest: compound 3; then compound 2; then compounds 4 and 1 (each within the scatter of the next).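

In this assay, swapping 4-methoxyphenyl for 5-methoxypyridin-3-yl at this position on the pyrazole-free account of the shared core gives a 10-fold higher number from compound 3 to compound 4 (1.00 log units; beyond the scatter), a step about as large as the earlier 10-fold lower number from compound 1 to compound 3 (1.02 log units; beyond the scatter), though in the opposite direction. Keeping a methoxy group on the ring is therefore not enough to hold the lower number, and with a 1.0-fold lower number from compound 1 to compound 4 (0.02 log units; within the scatter), 5-methoxypyridin-3-yl and pyrimidin-5-yl cannot be told apart here, so the gain seen with 4-methoxyphenyl is absent for both rings that contain nitrogen. No measurement is available that explains this loss.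

The names 4-methoxyphenyl and 5-methoxypyridin-3-yl also differ in where the methoxy group stands, so the compounds shown do not separate the ring nitrogen from that shift. From the compounds shown here alone, how a plain phenyl ring, or a phenyl ring carrying its methoxy group where 5-methoxypyridin-3-yl carries it, would stand in this assay remains open, and such a pair would show which of the two differences carries the step.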